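Swapping the substituted phenyl ring for furan

A few compounds are considered here, and "the series" means these few. Any claim that something is new, unique, unknown or untested is made for them only; others in the source may bear on it.

In a functional assay on MCF7 cells (Homo sapiens) for cytotoxicity, read by MTT assay, with a stated time of 72 h (on this read-out lower numbers stand for stronger inhibition and higher numbers for weaker inhibition), compound 1 `COc1cccc(C=C2C(=O)N(c3ccc(Cl)cc3)N(c3ccc(Cl)cc3)C2=O)c1O` gives 26700 nM, the highest of the three numbers recorded. Compound 2 `COc1cccc(C=C2C(=O)N(c3ccc(Cl)cc3)N(c3ccc(Cl)cc3)C2=O)c1` gives 18100 nM, and compound 3 `COc1cccc(C=C2C(=O)N(c3ccc(Cl)cc3)N(c3ccc(Cl)cc3)C2=O)c1OC` gives 11900 nM. Compound 4 `O=C1C(=Cc2ccco2)C(=O)N(c2ccc(Cl)cc2)N1c1ccc(Cl)cc1` carries the change (furan-2-yl in place of 2-hydroxy-3-methoxyphenyl on a double-bonded chain carbon bound to a double-bonded ring carbon). Within the data shown here, two measured steps bear on it: the hydroxy is taken away in a 1.5-fold lower number from compound 1 to compound 2 (0.17 log units; within the scatter), and it is capped by a methyl in a 2.2-fold lower number from compound 1 to compound 3 (0.35 log units; beyond the scatter). Neither compound 2 nor compound 3 keeps the hydroxy group, and compound 4 has none either; both steps lowered the number only slightly. Among the measured compounds shown here, no measured step exchanges the whole ring, so a modest downward step is expected, a 1.8-fold lower number from compound 1 to compound 4 (0.25 log units; within the scatter). Compound 4 is therefore estimated at 15000 nM, with a range from 6000 nM to 40000 nM.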

Compound 4, half-maximal inhibitory concentration: 20300 nM
The estimate for compound 4 lay 1.4-fold (0.13 log units) below the measured number, within the range that was stated.
By their numbers in this assay, from the lowest: compounds 3, 2, 4 and 1 (each within the scatter of the next, the first and the last beyond it).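

In this assay, the whole 2-hydroxy-3-methoxyphenyl ring gives way to furan-2-yl with little effect (a 1.3-fold lower number from compound 1 to compound 4 (0.12 log units; within the scatter)). The two other rings compare the same way (a 1.7-fold higher number from compound 3 to compound 4 (0.23 log units; within the scatter)) and (a 1.1-fold higher number from compound 2 to compound 4 (0.05 log units; within the scatter)), so the earlier changes to groups on the ring now extend to exchanging the ring itself, with every step within the scatter. Nothing measured here explains why these numbers stay so close.

On these data alone, whether an amine or a carboxylic acid at this place would move the number remains open. So does whether furan-2-yl would behave alike on a different core.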